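Thiophene for chlorophenyl at the imine carbon

The compounds below may be only part of what the source reports. "The series", "measured", "known", "first", "only" and "open" are said of these compounds alone.

Compound 1 `COc1ccc(/C=N/NC(=S)NC(C)(C)[C@H]2CC=C(C)CC2)cc1` carries a methoxy group on an aromatic carbon and shares its core with the two compounds below. In a functional assay on 786-0 cells (Homo sapiens) for inhibition, read by sulforhodamine B assay, with a stated time of 48 h (a lower number here means a stronger inhibitor of growth, a higher number a weaker inhibitor of growth), compound 1 gives 29600 nM. Compound 2 `CC1=CC[C@H](C(C)(C)NC(=S)N/N=C/c2ccc(Cl)cc2)CC1` differs from it by chloro in place of methoxy on an aromatic carbon. In this assay compound 2 reaches only a limit, > 100000 nM, which is the limit of > 100000 nM in this assay, at which 1 of the 2 values shown sits. The step of an at least 3.3-fold higher number from compound 1 to compound 2 (0.52 log units; beyond the scatter) is known only as a lower bound on its size.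

Compound 3 `CC1=CC[C@H](C(C)(C)NC(=S)N/N=C/c2cccs2)CC1` is not yet measured. It differs from compound 2 by thiophen-2-yl in place of 4-chlorophenyl on a carbon with a double bond to nitrogen. For the measured compounds named here, no measured step touches the exchange of the whole aromatic ring; the single measured step, an at least 3.3-fold higher number from compound 1 to compound 2 (0.52 log units; beyond the scatter), concerns a substituent on that ring and gives little guidance for compound 3. The expected step of an at least 1.1-fold lower number from compound 2 to compound 3 (0.04 log units; that floor lies within the scatter) is set at about none beyond the scatter. The starting value is a limit, and a further limit is as likely as a number. For compound 3 in this assay a value of 90000 nM is estimated, with a range from 25000 nM to 200000 nM.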

Compound 3, concentration for total growth inhibition: 26700 nM
Compound 3: the middle estimate sits 3.4-fold (0.53 log units) above what was measured; the measured number falls inside the stated range.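

In this assay the exchange of the whole aromatic ring on the carbon with a double bond to nitrogen can now be read: thiophen-2-yl in place of 4-chlorophenyl gives an at least 3.7-fold lower number from compound 2 to compound 3 (0.57 log units; beyond the scatter) and so shows that the weak end of this small set is not shared by every aromatic ring at this place. Thiophen-2-yl in place of 4-methoxyphenyl gives a 1.1-fold lower number from compound 1 to compound 3 (0.04 log units; within the scatter) and so separates compound 3 from compound 1 by nothing that can be read, which leaves 4-chlorophenyl as the only group of the three that stands apart here. The size of the step to compound 3 remains a lower bound, because compound 2 stands at a limit and not at a number: the limit of > 100000 nM in this assay, at which 1 of the 3 values shown sits.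

On these data alone, whether an unsubstituted phenyl, a furan-2-yl or a 4-aminophenyl group on this carbon would stay level with compound 3 and compound 1 remains open. So does whether the chloro group alone sets compound 2 apart, since a chloro group on the thiophene ring is not among the compounds shown.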